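Propylsulfanyl for Methylamino on a Uridine Monophosphate

The compounds below may be only part of what the source reports. "The series", "measured", "known", "first", "only" and "open" are said of these compounds alone.

Compound 3 `CNc1nc(=O)ccn1[C@@H]1O[C@H](COP(=O)(O)O)[C@@H](O)[C@H]1O` is the starting point. In an in vitro functional assay on 1321-N1 cells for agonist activity at P2Y purinoceptor 2 (Homo sapiens), read by scintillation proximity assay and inositol phosphate accumulation (a lower number here means that less compound is needed, a higher number that more compound is needed for the effect), compound 3 reports only the limit > 100000 nM, a boundary of the measurement rather than a number (the limit of > 100000 nM in this assay, at which 1 of the 3 values shown sits). Among the compounds with values here, compound 1 `COc1nc(=O)ccn1[C@@H]1O[C@H](COP(=O)(O)O)[C@@H](O)[C@H]1O` gives 9900 nM in this assay, and the step of an at least 10-fold higher number from compound 1 to compound 3 (1.00 log units; beyond the scatter), methylamino in place of methoxy, is the one measured step that bears on the change at hand. Compound 2 `CCCSc1nc(=O)ccn1[C@@H]1O[C@H](COP(=O)(O)OP(=O)(O)O)[C@@H](O)[C@H]1O` also carries propylsulfanyl, although it is not a single-change neighbour of compound 4. In this assay compound 2 gives 1200 nM.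

Compound 4 `CCCSc1nc(=O)ccn1[C@@H]1O[C@H](COP(=O)(O)O)[C@@H](O)[C@H]1O` has not yet been measured. Its change from compound 3 is propylsulfanyl in place of methylamino on an aromatic carbon. Since introducing methylamino raised the number at least modestly, removing it is expected to bring the number back down, and the value of compound 2 suggests propylsulfanyl is tolerated. The expected step is therefore an at least 12-fold lower number from compound 3 to compound 4 (1.09 log units; beyond the scatter), toward a lower number. Compound 4 is estimated at 8000 nM, within a range of 1500 nM to 50000 nM.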

Compound 4, half-maximal effective concentration: 4800 nM
Compound 4: middle estimate off by 1.7-fold (0.22 log units), on the high side, within the range that was stated.
By their numbers in this assay, from the lowest: compound 2; then compound 4; then compound 1. At a limit, above all of these: compound 3.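

Compared with methylamino, propylsulfanyl gives an at least 20-fold lower number from compound 3 to compound 4 (1.31 log units; beyond the scatter), so the group at this position, between two ring nitrogen atoms, strongly affects the read-out in this assay. Going by these compounds, compound 3 reports only a limit, so the full size of that step remains unknown: the limit of > 100000 nM in this assay, at which 1 of the 4 values shown sits. Propylsulfanyl also improves on methoxy on the monophosphate, with a 2.1-fold lower number from compound 1 to compound 4 (0.31 log units; beyond the scatter), while a hydrogen atom in place of the outer phosphate group gives a 4.0-fold higher number from compound 2 to compound 4 (0.60 log units; beyond the scatter), so the larger sulfur-linked chain still works with the shorter phosphate tail, at some cost.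

On these data alone, whether a shorter methylsulfanyl or a longer hexylsulfanyl chain would lower the number further remains open. The compounds shown also offer no measured property that explains the gap between methylamino and propylsulfanyl.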